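Chloro for methyl on the benzyl arm: half-life outlook

The source may report more compounds than this note shows. Statements on the series, on what has been measured and on what is new or still open speak of the compounds shown alone.

Measured compounds:
compound 1, `Cc1cc(S(=O)(=O)/N=C(\N)n2nccc2-c2ccccc2)c(SCc2ccc(Cl)cc2)cc1Cl`, 0.34 h
compound 2, `Cc1cc(-c2ccccc2)n(/C(N)=N/S(=O)(=O)c2cc(C)c(Cl)cc2SCc2ccccc2C)n1`, 0.154 h
compound 3, `Cc1cc(S(=O)(=O)/N=C(\N)n2nccc2-c2ccccc2)c(SCc2ccccc2C)cc1Cl`, 0.0802 h

All three were run in an ADME assay on microsomes from liver (Homo sapiens) for metabolic stability, read by LC-MS, using NADPH, tested at 5 uM; a higher number here means that the compound lasts longer, a lower number that the compound disappears faster. Compound 2 holds the second highest of the three numbers; its nearest neighbour is compound 3, and that gap a 1.9-fold lower number from compound 2 to compound 3 (0.28 log units; within the scatter), while the gap to compound 1, whose value is 0.34 h, lies beyond the scatter. The unmeasured compound 4, `Cc1cc(-c2ccccc2)n(/C(N)=N/S(=O)(=O)c2cc(C)c(Cl)cc2SCc2ccccc2Cl)n1`, differs from compound 2 in one place: chloro in place of methyl on an aromatic carbon.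

Of the measured steps, only one touches a chloro against a methyl on the benzyl arm: a 4.2-fold lower number from compound 1 to compound 3 (0.63 log units; beyond the scatter), a modest step beyond the scatter, though with the group at a different place on the ring. The other step, a 1.9-fold lower number from compound 2 to compound 3 (0.28 log units; within the scatter), concerns the pyrazole methyl and does not bear on the present change. On that single comparison the account expects compound 4 to last somewhat longer than compound 2, with a step of a 1.8-fold higher number from compound 2 to compound 4 (0.26 log units; within the scatter), though a result within the scatter would not surprise. The estimate for compound 4 in this assay is 0.28 h, with a range from 0.12 h to 0.65 h.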

Compound 4, half-life: 0.163 h
For compound 4 the middle estimate is 1.7-fold (0.23 log units) above the measured one, within the range that was stated.
By their numbers in this assay, from the lowest: compounds 3, 2 and 4 (each within the scatter of the next, the first and the last beyond it); then compound 1.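

In this assay, (2-chlorobenzyl)sulfanyl in place of (2-methylbenzyl)sulfanyl gives a 1.1-fold higher number from compound 2 to compound 4 (0.02 log units; within the scatter) and so, at this place ortho to a large group, the half-life does not separate chloro from methyl. The earlier compounds shown here offered only a 4.2-fold lower number from compound 1 to compound 3 (0.63 log units; beyond the scatter) as a guide, a step that exchanges 4-chlorophenyl for 2-methylphenyl and so moves the group as well as changing it; the new pair holds the place fixed, and that larger step does not reappear. Nothing given here accounts for the two compounds reading alike.

Going by these compounds, it remains open whether a methoxy group or a nitrile at this same place would shift the half-life beyond the scatter. Also open, on these data alone, is whether the exchange of methyl for chloro would read the same on the core of compound 3.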